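This account rests on a few compounds, and the source may have more. Where it says the series, first, only, none or still open, it means among the compounds named here.

In an ADME assay on S9 fraction from liver (Rattus norvegicus) for metabolic stability, with a stated time of 1 h (a lower number here means that less of the compound is left, a higher number that more of the compound is left), compound 1 `N#Cc1cnc(NCc2cncnc2C(F)(F)F)cc1N[C@H]1CC[C@@H](O)CC1` gives 76% and compound 2 `CC(C)(F)c1ncncc1CNc1cc(N[C@H]2CC[C@@H](O)CC2)c(C#N)cn1` gives 81%, so the two sit within the scatter of each other. Compound 3 `N#Cc1cnc(NCc2cncnc2-c2ccccc2)cc1N[C@H]1CC[C@@H](O)CC1` has phenyl in place of 1-fluoro-1-methylethyl on an aromatic carbon. Within the data shown here, the one measured step at this place, a number 5 percentage points higher from compound 1 to compound 2 (within the scatter), bears only loosely, since neither compound 1 nor compound 2 has a ring there. The data therefore give no direct guide to a phenyl group. A modest fall in this assay is expected, an estimated a number 15 percentage points lower from compound 2 to compound 3 (beyond the scatter). The expected value for compound 3 is 66%, with an estimated range of 45% to 84%.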

Compound 3, percent of the compound remaining: 78%
Compound 3: the middle estimate sits 12 percentage points below what was measured, within the range that was stated.
By their numbers in this assay, from the lowest: compounds 1, 3 and 2 (each within the scatter of the next).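

In this assay, phenyl on this aromatic carbon brings a number 3 percentage points lower from compound 2 to compound 3 (within the scatter) and a number 2 percentage points higher from compound 1 to compound 3 (within the scatter). A six-membered aromatic ring can therefore stand at this position without moving the number beyond the scatter, which the two ringless groups, trifluoromethyl and 1-fluoro-1-methylethyl, could not show. Nothing available explains this result.

Still open, as far as these compounds go, is whether phenyl carrying a substituent, or a ring with nitrogen such as pyridyl, would keep the number within that scatter. From the compounds shown here alone, an amine at this position also remains untested in these compounds.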